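The source may hold more compounds than are shown below. What is called first, only, known or untested is meant among the compounds shown, and "the series" means these compounds.

The measured compounds are compound 1 `CN1CCN(c2ccc(Nc3ncc4nc(Nc5ccc(F)cc5)n([C@@H]5CCCN(C(=O)CO)C5)c4n3)cc2)CC1` with 66 nM and compound 2 `CNC(=O)CN1CC[C@H](n2c(Nc3ccc(F)cc3)nc3cnc(Nc4ccc(N5CCN(C)CC5)cc4)nc32)C1` with 1520 nM. In a functional assay on HCC827 cells (Homo sapiens) for antiproliferative activity, read by MTT assay, with a stated time of 72 h (a higher number here means a weaker inhibitor, a lower number a stronger inhibitor), compound 2 gives the highest of the two numbers, and its nearest neighbour is compound 1, separated by a 23-fold higher number from compound 1 to compound 2 (1.36 log units; beyond the scatter).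

Compound 3 `CN1CCN(c2ccc(Nc3ncc4nc(Nc5ccc(F)cc5)n([C@@H]5CCN(C(=O)OC(C)(C)C)C5)c4n3)cc2)CC1` has not yet been measured. It differs from compound 2 in one place: 1-(tert-butoxycarbonyl)pyrrolidin-3-yl in place of 1-((methylcarbamoyl)methyl)pyrrolidin-3-yl on an aromatic nitrogen. Among the compounds with values here, only one measured step bears on this position, the step from compound 1 to compound 2, which was large at a 23-fold higher number from compound 1 to compound 2 (1.36 log units; beyond the scatter); it shows that the group on this aromatic nitrogen can move the number well beyond the scatter. Within the data shown here, no measured pair shows a tert-butoxycarbonyl group at this position, so the direction for compound 3 is not fixed by the data. Since compound 2 stands at the high end, a change at the same place is expected to give a step of a 3.4-fold lower number from compound 2 to compound 3 (0.53 log units; beyond the scatter), with a lower number more likely than a higher one. Compound 3 is therefore expected to give about 450 nM in this assay, in a range from 100 nM to 1800 nM.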

Compound 3, half-maximal inhibitory concentration: 27 nM
Compound 3: middle estimate off by 17-fold (1.22 log units), on the high side; the whole stated range lies above it.
By their numbers in this assay, from the lowest: compound 3; then compound 1; then compound 2.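

In this assay, replacing the 1-((methylcarbamoyl)methyl)pyrrolidin-3-yl group with 1-(tert-butoxycarbonyl)pyrrolidin-3-yl gives a 56-fold lower number from compound 2 to compound 3 (1.75 log units; beyond the scatter), so the five-membered ring of compound 2 does not by itself bring the high number, and the group on the ring nitrogen can shift the number widely while the ring stays the same. The other new step, a 2.4-fold lower number from compound 1 to compound 3 (0.39 log units; beyond the scatter), is modest but beyond the scatter, which shows that a pyrrolidin-3-yl group on the aromatic nitrogen can give a lower number than the 1-((hydroxymethyl)carbonyl)piperidin-3-yl group, although ring size and ring-nitrogen substituent change together in this step. Nothing in the available data accounts for the size or direction of either step.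

The three compounds leave open how much of the difference belongs to ring size and how much to the ring-nitrogen substituent, a question that a 1-((hydroxymethyl)carbonyl)pyrrolidin-3-yl group or a 1-(tert-butoxycarbonyl)piperidin-3-yl group would address. They also leave open how the number responds at this ring nitrogen to a free secondary amine, a carboxylic acid on a short chain, or a methyl carbamate.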